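Iodo to phenoxy: a modest rise expected

This account rests on a few compounds, and the source may have more. Where it says the series, first, only, none or still open, it means among the compounds named here.

Of the compounds shown here, three sharing one core have been measured in a physicochemical assay for lipophilicity; on this read-out higher numbers stand for higher lipophilicity and lower numbers for lower lipophilicity. Compound 1 `Fc1ccccc1C1=NC(c2ccccc2)CO1` gives 3.51, compound 2 `CCSc1ccccc1C1=NC(c2ccccc2)CO1` gives 4.04, and compound 3 `Ic1ccccc1C1=NC(c2ccccc2)CO1` gives 3.86. The numbers show a number 0.35 log units higher from compound 1 to compound 3 (beyond the scatter), but a number 0.18 log units lower from compound 2 to compound 3 (within the scatter). Compound 3 therefore stands clear of the fluoro compound but not apart from the ethylsulfanyl one.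

Compound 4 `c1ccc(Oc2ccccc2C2=NC(c3ccccc3)CO2)cc1` carries phenoxy in place of iodo on an aromatic carbon. Among the compounds with values here, no measured step involves phenoxy, so the nearest guides are the modest steps of a number 0.53 log units higher from compound 1 to compound 2 (beyond the scatter) and a number 0.35 log units higher from compound 1 to compound 3 (beyond the scatter). In this assay, a modest upward change is expected, estimated as a number 0.44 log units higher from compound 3 to compound 4 (beyond the scatter). Compound 4 is estimated at 4.3, with an expected range from 3.9 to 4.8.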

Compound 4, partition coefficient: 5.61
Beside the measured number, compound 4's estimate is 1.31 log units below it; the measured number lies above the stated range.
By their numbers in this assay, from the lowest: compound 1; then compounds 3 and 2 (each within the scatter of the next); then compound 4.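

In this assay, within the data shown here, the change at this place, on an aromatic carbon ortho to a large group, can be far larger than the earlier compounds showed, with steps of a number 1.75 log units higher from compound 3 to compound 4 (beyond the scatter) and a number 1.57 log units higher from compound 2 to compound 4 (beyond the scatter) and a number 2.10 log units higher from compound 1 to compound 4 (beyond the scatter) all large. Among the four groups compared here, only phenoxy brings its own six-membered aromatic ring of carbon only. Nothing available explains the size of this rise.

The compounds shown leave open whether the ring or the oxygen of phenoxy accounts for the rise. A phenyl or a methoxy group at the same place would separate the two.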